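Compound 1 and a single side-chain swap

The source may hold more compounds than are shown below. What is called first, only, known or untested is meant among the compounds shown, and "the series" means these compounds.

Measured in a physicochemical assay for solubility, in phosphate buffer, measured as kinetic solubility, with a stated time of 1 h, at pH 7.4; on this read-out higher numbers stand for higher solubility and lower numbers for lower solubility:
compound 1 `CCNC(=O)Nc1ccc(-c2nc(CS(C)(=O)=O)cc([C@]34CCOC[C@H]3C4)n2)cc1` (96 ug/mL)
compound 2 `CC(C)(c1cc([C@@]23CCOC[C@@H]2C3)nc(-c2ccc(NC(=S)NCCO)cc2)n1)S(C)(=O)=O` (145 ug/mL)

Compound 1 and compound 2 are the only two measured so far, and their values lie within the usual scatter of each other, so compound 1 stands level with compound 2 on these numbers. Compound 3 `CCNC(=O)Nc1ccc(-c2nc(C(C)(C)S(C)(=O)=O)cc([C@]34CCOC[C@H]3C4)n2)cc1` keeps the core of compound 1 and differs from it at one place, on an aromatic carbon: 1-methyl-1-(methylsulfonyl)ethyl in place of (methylsulfonyl)methyl on an aromatic carbon and the rest of the structure stays the same. Among the compounds with values here, no measured pair shows this change on its own, so the data give no direct size for it. In this assay only a small step is expected, none beyond the scatter and in no firm direction. The estimated change is a 1.1-fold lower number from compound 1 to compound 3 (0.05 log units; within the scatter) and it remains an expectation. For compound 3 the expected value is 85 ug/mL with an estimated range from 35 ug/mL to 200 ug/mL on this read-out.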

Compound 3, solubility: 74 ug/mL
The estimate for compound 3 lay 1.1-fold (0.06 log units) above the measured number; low and high end bracket the measured number.
By their numbers in this assay, from the lowest: compounds 3, 1 and 2 (each within the scatter of the next).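

Within the data shown here, for the swap of (methylsulfonyl)methyl to 1-methyl-1-(methylsulfonyl)ethyl on this aromatic carbon, this assay now gives a direct size, with a 1.3-fold lower number from compound 1 to compound 3 (0.11 log units; within the scatter) as the first reading of this change on its own. At this place, next to the ring nitrogen, going from 5 to 7 heavy atoms with no change in hydrogen-bond donors or acceptors does not carry the solubility number beyond the scatter. No measurement at hand gives a reason for the size of this step.

The compounds shown leave open whether another kind of group at this place, such as an amine, a carboxylic acid or a longer chain, would give a step beyond the scatter. They also leave open whether the same swap would read alike on a compound other than compound 1.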